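Fluoro to methoxy on the pyrazole-series aryl ring

The source may hold more compounds than are shown below. What is called first, only, known or untested is meant among the compounds shown, and "the series" means these compounds.

Measured so far:
- compound 1, `O=C1COc2ccc(-c3[nH]c(-c4ccc(C(F)(F)F)cc4)nc3-c3ccccc3)cc2N1`, giving 12.1%
- compound 2, `COc1ccc(-c2nc(-c3ccccc3)c(-c3ccc4c(c3)NC(=O)CO4)[nH]2)cc1`, giving 19.1%
- compound 3, `O=C1COc2ccc(-c3nn(-c4ccc(F)cc4)cc3-c3ccccc3)cc2N1`, giving 45.2%

In a functional assay on DLD-1 cells (Homo sapiens) for cytotoxicity, read by colorimetric assay and MTT assay, with a stated time of 3 days, tested at 20 uM (on this read-out higher numbers stand for a weaker effect at the one concentration tested and lower numbers for a stronger effect), compound 3 stands highest of the three numbers, the weakest effect at the one concentration tested. Its nearest neighbour is compound 2, whose number is lower by a margin beyond the scatter, and compound 1 lies further still below it, also beyond the scatter.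

Compound 4, `COc1ccc(-n2cc(-c3ccccc3)c(-c3ccc4c(c3)NC(=O)CO4)n2)cc1`, differs from compound 3 in one place: methoxy in place of fluoro on an aromatic carbon. The group sits para to a large group on a six-membered aromatic ring of carbon only.

For the measured compounds named here, the one measured step that bears on this is the exchange of a small substituent for methoxy at the same position of compound 1 and compound 2: a number 7 percentage points higher from compound 1 to compound 2 (within the scatter). That step is within the scatter. Going by the values given here, since no other pair speaks to a change at this position, and the only comparable step is small, the expected step of a number 2.8 percentage points higher from compound 3 to compound 4 (within the scatter) is likewise one not beyond the scatter, in no fixed direction. Compound 4 is therefore expected to give about 48% in this assay, estimated to lie between 30% and 68%.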

Compound 4, a percentage reported as activity, at one concentration (the size of the read-out at that concentration, not a potency): 35.6%
Estimate against measurement, compound 4: 12.4 percentage points above; the measured number falls inside the stated range.
By their numbers in this assay, from the lowest: compounds 1 and 2 (each within the scatter of the next); then compounds 4 and 3 (each within the scatter of the next).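

In this assay the exchange of 4-fluorophenyl for 4-methoxyphenyl gives a number 9.6 percentage points lower from compound 3 to compound 4 (within the scatter) and so, at this place para to a large group, the readings of the two compounds cannot be told apart. The earlier compounds shown here showed methoxy only in place of trifluoromethyl, with a number 7 percentage points higher from compound 1 to compound 2 (within the scatter) on a different core, so methoxy has now been exchanged on an aromatic carbon in two pairs and neither step lies beyond the scatter, a pattern claimed for these two pairs alone. Nothing available accounts for either reading, and no measured property of the fluoro or methoxy group bears on this result.

As far as these compounds go, what remains open is whether a group of another kind on the same aromatic carbon, such as an amine, a carboxylic acid or a longer alkoxy chain, would give a step beyond the scatter. The compounds shown also leave open how the reading would respond to hydrogen at this place, and whether a change on the unsubstituted phenyl ring of compound 4 would matter more than one on the methoxy-bearing ring.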